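A Single Ring Inversion Against a Full Mirror Image

A few compounds are considered here, and "the series" means these few. Any claim that something is new, unique, unknown or untested is made for them only; others in the source may bear on it.

Compound 1, `O=C(N[C@H](CO)C(=O)O)[C@@H]1C[C@@H](O)CN1`, is the reference point. For the measured compounds named here, in an ADME assay on Jejunum (Mus musculus, strain C57BL/6) for metabolic stability, read by HPLC, with a stated time of 12 h (on this read-out lower numbers stand for a shorter-lived compound and higher numbers for a longer-lived compound), compound 1 gives 0.39 h, the only numeric value in the set. Compound 2, `O=C(O)[C@H](CO)NC(=O)[C@H]1C[C@H](O)CN1`, reaches a limit of the assay: in this assay compound 2 gives > 12 h. The step of an at least 30-fold higher number from compound 1 to compound 2 (1.48 log units; beyond the scatter) is therefore known only as a lower bound, because the limit of > 12 h in this assay, at which 1 of the 2 values shown sits, and because of the fact that compounds 1 and 2 differ only in the configuration as drawn.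

Compound 3, `O=C(O)[C@@H](CO)NC(=O)[C@H]1C[C@@H](O)CN1`, differs from compound 1 as follows: the two compounds have the same atoms and bonds and differ only in configuration as drawn: 1 of 3 stereo elements differ; a stereocentre at a saturated ring carbon is drawn S in compound 1 and R in compound 3.

Only the full mirror-image step bears on this change, and it is large, but it inverts all three stereocentres at once, whereas compound 3 inverts only one of them. Going by the values given here, no measured pair isolates that single ring inversion, so its direction is not fixed by the data. A moderately longer half-life is expected, with wide uncertainty; the step of a 3.8-fold higher number from compound 1 to compound 3 (0.59 log units; beyond the scatter) is the estimated outcome. Compound 3 is expected at 1.5 h, between 0.3 h and 8 h.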

Compound 3, half-life: > 12 h
Compound 3 was reported as a limit (the forecaster's own chance of this, stated with the estimate: 15%); at least 8.0-fold (0.90 log units) between middle value and limit.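

Inverting one stereocentre at a saturated ring carbon, from S to R, is enough on its own for an at least 30-fold higher number from compound 1 to compound 3 (1.48 log units; beyond the scatter) in this assay. Compound 3 gives > 12 h, which is a limit, so the step is known only as a lower bound. The full mirror image of compound 1 is thus not needed to reach the limit, and the gain is tied to configuration alone: the fact that compounds 1 and 3 differ only in the configuration as drawn

Compound 2 and compound 3 both sit at the limit, so the step between them cannot be read, and neither can be ranked against the other. Also open, from the compounds shown here alone, is whether the saturated chain stereocentre matters on its own, and whether the ring inversion would have the same outcome with a methyl ester in place of the carboxylic acid.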